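Chloro position on the terminal phenyl: cytotoxicity notes

This account rests on a few compounds, and the source may have more. Where it says the series, first, only, none or still open, it means among the compounds named here.

In a toxicity assay on MT4 cells (Homo sapiens) for cytotoxicity, read by MTT assay (on this read-out lower numbers stand for higher toxicity in this test and higher numbers for lower toxicity in this test), compound 1 (`Cc1cc(-c2ccccc2)cc(C)c1Oc1cc(N)nc(Nc2ccc(C#N)cc2)n1`) gives 25600 nM and compound 2 (`Cc1cc(-c2ccccc2Cl)cc(C)c1Oc1cc(N)nc(Nc2ccc(C#N)cc2)n1`) gives 25100 nM. Compound 2 therefore has a single comparator, and the two values lie within the scatter of each other.

Compound 3 (`Cc1cc(-c2ccc(Cl)cc2)cc(C)c1Oc1cc(N)nc(Nc2ccc(C#N)cc2)n1`) has not yet been measured. It differs from compound 2 by one structural change: 4-chlorophenyl in place of 2-chlorophenyl on an aromatic carbon. The swap is 4-chlorophenyl in place of 2-chlorophenyl, on an aromatic carbon meta to two methyl groups and para to a large group.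

Among the measured compounds shown here, only one measured step bears on this change, and it is indirect: a 1.0-fold lower number from compound 1 to compound 2 (0.01 log units; within the scatter), with chloro in place of hydrogen on an aromatic carbon. That step stays within the scatter. For the measured compounds named here, no measured compound yet carries the 4-chlorophenyl group, so the evidence is thin and the range must stay wide.

In this assay, no change beyond the scatter is expected, and the estimated step is a 1.0-fold lower number from compound 2 to compound 3 (0.02 log units; within the scatter). Compound 3 is expected at 24000 nM, with an estimated range of 11000 nM to 50000 nM.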

Compound 3, half-maximal cytotoxic concentration: 21500 nM
The estimate for compound 3 lay 1.1-fold (0.05 log units) above the measured number, and the stated range covers the measured number.
By their numbers in this assay, from the lowest: compounds 3, 2 and 1 (each within the scatter of the next).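

Working notes on chloro placement, continued.

In this assay, the exchange of 2-chlorophenyl for 4-chlorophenyl gives a 1.2-fold lower number from compound 2 to compound 3 (0.07 log units; within the scatter) and stays inside the usual spread of repeat measurements. Compound 3 adds a second chloro placement to the comparison with the unsubstituted phenyl, with a 1.2-fold lower number from compound 1 to compound 3 (0.08 log units; within the scatter) also inside that spread. Across compounds 1, 2 and 3, neither adding chloro to the phenyl group nor changing its place between these two arrangements separates the numbers in this test, and no compound in the set goes against that reading.

No measurement at hand gives a reason for this flat result, and none bears on what the chloro group does in these compounds.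

The three compounds leave open whether a group other than chloro on this phenyl ring, such as an amine, a carboxylic acid or a longer alkyl chain, would move the number beyond the scatter. They also leave open whether the same flat picture would hold on another core, since all three share a single one and are compared here on this one cytotoxicity read-out.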